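Aryl Variation on the Shared Core: Outlook for Compound 4

This account rests on a few compounds, and the source may have more. Where it says the series, first, only, none or still open, it means among the compounds named here.

compound 1 `CCC1=C(O)c2c(oc(-c3ccc(C(C)C)cc3)cc2=O)C(CC)(CC)C1=O` — 1.08 uM
compound 2 `CCC1=C(O)c2c(oc(-c3ccccc3C)cc2=O)C(CC)(CC)C1=O` — 2.41 uM
compound 3 `CCC1=C(O)c2c(oc(-c3ccccc3OC)cc2=O)C(CC)(CC)C1=O` — 3.26 uM

In a functional assay on KBVIN cells (Homo sapiens) for antiproliferative activity, read by sulforhodamine B assay, with a stated time of 3 days (a higher number here means that more compound is needed for the effect, a lower number that less compound is needed), compound 1 gives the lowest of the three numbers; its nearest neighbour is compound 2 and the furthest is compound 3. Compound 4 `CCC1=C(O)c2c(oc(-c3cc(C)c(C)cc3C)cc2=O)C(CC)(CC)C1=O` has not been measured; it differs from compound 1 by 2,4,5-trimethylphenyl in place of 4-isopropylphenyl on an aromatic carbon. Among the measured compounds shown here, two measured steps bear on this change, a 2.2-fold higher number from compound 1 to compound 2 (0.35 log units; beyond the scatter) and a 3.0-fold higher number from compound 1 to compound 3 (0.48 log units; beyond the scatter), each exchanging the 4-isopropylphenyl for a differently substituted phenyl and each raising the number modestly. Between those two products the gap, a 1.4-fold higher number from compound 2 to compound 3 (0.13 log units; within the scatter), stays within the scatter. A modest rise is therefore expected for compound 4 as well, a 2.0-fold higher number from compound 1 to compound 4 (0.31 log units; beyond the scatter). Compound 4 is estimated at 2.2 uM, within a range of 0.9 uM to 5 uM.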

Compound 4, concentration for half-maximal effect: 4.37 uM
Compound 4: the middle estimate sits 2.0-fold (0.30 log units) below what was measured; the range from low to high includes it.
By their numbers in this assay, from the lowest: compound 1; then compounds 2, 3 and 4 (each within the scatter of the next).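

At this position, next to the ring oxygen, 2,4,5-trimethylphenyl has the same heavy-atom count as the 4-isopropylphenyl it replaces, yet this assay still shows a 4.0-fold higher number from compound 1 to compound 4 (0.61 log units; beyond the scatter). The new group does not separate from the other two replacements, with a 1.3-fold higher number from compound 3 to compound 4 (0.13 log units; within the scatter) and a 1.8-fold higher number from compound 2 to compound 4 (0.26 log units; within the scatter), so only compound 1 stands apart from the rest. No measured evidence accounts for this result.

Still open, as far as these compounds go, is whether a longer chain in place of the isopropyl keeps the number near that of compound 1. From the compounds shown here alone, the effect of an amine or a carboxylic acid on the phenyl also remains open.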